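This account rests on a few compounds, and the source may have more. Where it says the series, first, only, none or still open, it means among the compounds named here.

Compound 1 `Cc1ccc(NC(=S)Nn2c(S)nnc2-c2ccncc2)cc1` and compound 2 `S=C(Nc1ccc(Br)cc1)Nn1c(S)nnc1-c1ccncc1` share one core and differ only at one ring position. In a functional assay on NUGC cells (Homo sapiens) for cytotoxicity, read by sulforhodamine B assay, with a stated time of 24 h (on this read-out lower numbers stand for stronger inhibition and higher numbers for weaker inhibition), compound 1 gives 2770 nM, and compound 2 gives 3290 nM. The step of a 1.2-fold higher number from compound 1 to compound 2 (0.07 log units; within the scatter) follows the change (bromo in place of methyl on an aromatic carbon). Compound 3 `Cc1ccc(Nc2nn3c(-c4ccncc4)nnc3s2)cc1` rests on a different core; how the two cores differ is not broken down here. In this assay compound 3 gives 540 nM, the lowest number of the three. For the measured compounds named here, compound 4 `Brc1ccc(Nc2nn3c(-c4ccncc4)nnc3s2)cc1` is still to be measured in this assay and differs from compound 3 by bromo in place of methyl on an aromatic carbon, the same change in the same place as the one between compound 1 and compound 2. Because that earlier change gave a 1.2-fold higher number from compound 1 to compound 2 (0.07 log units; within the scatter), a step of similar size is expected here, namely a 1.2-fold higher number from compound 3 to compound 4 (0.07 log units; within the scatter). Compound 4 is therefore estimated at 640 nM, between 320 nM and 1300 nM.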

Compound 4, half-maximal inhibitory concentration: 136 nM
Beside the measured number, compound 4's estimate is 4.7-fold (0.67 log units) above it; measured number below the stated range.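

In this assay, bromo in place of methyl on an aromatic carbon gives a 4.0-fold lower number from compound 3 to compound 4 (0.60 log units; beyond the scatter). This step does not match the earlier one, so the change cannot be carried unaltered from the core of compound 1 to the core of compound 3: the same change on two cores in this assay, a 1.2-fold higher number (0.07 log units; within the scatter) from compound 1 to compound 2 and a 4.0-fold lower number (0.60 log units; beyond the scatter) from compound 3 to compound 4, 4.7-fold (0.67 log units) apart, beyond the scatter of two such steps. For the compounds shown here, the result shows that the outcome of this change differed between these two cores, but with only two pairs it does not show why, or how the change would behave on any further core.

The compounds shown leave open whether a chloro group, a methoxy group or an amine in the same place would also give different steps on the two cores. They also leave open whether the lower number of compound 4 would hold in other cells.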